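Ethyl ester next in the brine shrimp series

A few compounds are considered here, and "the series" means these few. Any claim that something is new, unique, unknown or untested is made for them only; others in the source may bear on it.

Going by the values given here, compound 2 `CO[C@H]1C[C@H](O[Si](C)(C)C(C)(C)C)O[C@@H](C)/C1=C/C=O` is the aldehyde of the series; in a functional assay on the whole organism for inhibition, with Artemia salina as the target (a lower number here means a stronger inhibitor of growth, a higher number a weaker inhibitor of growth), compound 2 gives 0.01 ug/mL, the highest of the two numbers measured so far. Its nearest neighbour is compound 1 `C=CCOC(=O)/C=C1/[C@H](C)O[C@@H](O[Si](C)(C)C(C)(C)C)C[C@@H]1OC`, the allyl ester, which in this assay gives 0.002 ug/mL. Among the compounds with values here, the single measured step joining them, a number 2.3 two-fold dilutions higher from compound 1 to compound 2 (beyond the scatter), is hydrogen in place of allyloxy on the carbonyl carbon, and it weakened inhibition beyond the scatter. Compound 3 `CCOC(=O)/C=C1/[C@H](C)O[C@@H](O[Si](C)(C)C(C)(C)C)C[C@@H]1OC` reverses that kind of change: ethoxy in place of hydrogen on a carbonyl carbon. Within the data shown here, the only step that bears on this is the one from compound 1 to compound 2; ethoxy and allyloxy differ only in their chain, so a step of similar size in the opposite direction, towards a lower number in this assay, is expected. For compound 3 the expected step is a number 1.7 two-fold dilutions lower from compound 2 to compound 3 (beyond the scatter). Compound 3 is therefore estimated at 0.003 ug/mL, within a range from 0.001 ug/mL to 0.01 ug/mL.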

Compound 3, minimum inhibitory concentration: 0.01 ug/mL
Estimate against measurement, compound 3: 1.7 two-fold dilutions below; the measured number falls inside the stated range.
By their numbers in this assay, from the lowest: compound 1; then compounds 2 and 3 (each within the scatter of the next).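

In this assay ethoxy in place of hydrogen on a carbonyl carbon gives no change at the digits printed from compound 2 to compound 3 (within the scatter) and so, at this position, the formyl to ethoxycarbonyl change alone does not reach the level of compound 1. The ester function is therefore not sufficient in this pair, and the two esters separate with a number 2.3 two-fold dilutions higher from compound 1 to compound 3 (beyond the scatter) as methyl stands in place of vinyl on a saturated chain carbon bound to an oxygen next to a carbonyl group. No evidence on the cause of this difference is available.

Whether the vinyl end itself is required remains open, since only the allyl and ethyl esters are shown. A propyl or benzyl ester, a carboxylic acid or an amide at this carbonyl carbon would test whether the level of compound 1 is specific to the allyl chain.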